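This account rests on a few compounds, and the source may have more. Where it says the series, first, only, none or still open, it means among the compounds named here.

In a functional assay on the whole organism for inhibition, with Cavia porcellus as the target (on this read-out higher numbers stand for an effect only at larger amounts of compound and lower numbers for an effect already at smaller amounts), compound 1 `CN(C)/C(=N\C#N)C1=CC(C)(C)Oc2ccc([N+](=O)[O-])cc21` gives 51.3 nM. Compound 2 `CN(C)/C(=N\C#N)C1=CC(C)(C)Oc2ccc(Br)cc21` reaches only a limit of this assay, namely > 31600 nM. The change of bromo in place of nitro produced an at least 610-fold higher number from compound 1 to compound 2 (2.78 log units; beyond the scatter), so compound 2 stands at the weak end of the two values shown. Compound 3 `CN(C)/C(=N\C#N)C1=CC(C)(C)Oc2ccccc21` differs from compound 2 by hydrogen in place of bromo on an aromatic carbon. No measured step covers a bromo-to-hydrogen exchange, and the only step shown shows how far a change at this aromatic carbon can move this assay. Compound 3 is therefore expected to remain weak, with an estimated at least 1.5-fold lower number from compound 2 to compound 3 (0.19 log units; that floor lies within the scatter) and an estimated value of 20000 nM, ranging from 3000 nM to 100000 nM.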

Compound 3, half-maximal effective concentration: > 31600 nM
Compound 3: only a limit was reported; the forecaster's own chance of this, stated with the estimate: 50%; middle value at least 1.5-fold (0.19 log units) from the limit.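

In this assay, hydrogen in place of nitro on this aromatic carbon gives an at least 610-fold higher number from compound 1 to compound 3 (2.78 log units; beyond the scatter), so the loss seen with bromo also appears with no substituent there. Of the three compounds, only compound 1, with nitro, gives a value that is not a limit, 51.3 nM. The step from compound 2 to compound 3 cannot be read, because both sit at the same limit: the limit of > 31600 nM in this assay, at which 2 of the 3 values shown sit.

From the compounds shown here alone, it remains open whether any other group at this carbon, such as an amine or a carboxylic acid, would give a value short of that limit. Going by these compounds, how far compound 2 and compound 3 lie beyond it also remains unknown.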